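Propylcarbonyl in Place of Cyclohexylmethyl: Expected Tolerance

The compounds below may be only part of what the source reports. "The series", "measured", "known", "first", "only" and "open" are said of these compounds alone.

Compound 1, `O=C(CC1CCCCC1)N1CCN(c2nc(=O)c3cc(C(F)(F)F)cc([N+](=O)[O-])c3s2)CC1`, gives > 125000 nM in an ADME assay on Vero cells (Chlorocebus sabaeus) for cytotoxicity, read by MTT assay, with a stated time of 72 h; a lower number here means that less compound is tolerated, a higher number that more compound is tolerated; this is a limit of the assay, not a number.
Compound 2, `O=c1nc(N2CCN(CC3CCCCC3)CC2)sc2c([N+](=O)[O-])cc(C(F)(F)F)cc12`, gives > 125000 nM in this assay; this too is a limit.
Compound 3, `O=C(c1ccccc1Cl)N1CCN(c2nc(=O)c3cc(C(F)(F)F)cc([N+](=O)[O-])c3s2)CC1`, gives > 125000 nM in this assay; this also is a limit.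

Within the data shown here, compound 2 thus stands where every compound measured so far stands: at the limit of > 125000 nM in this assay, at which 3 of the 3 values shown sit, with no number of its own. The three measured steps, a step that the two limits leave unreadable from compound 1 to compound 2, a step that the two limits leave unreadable from compound 1 to compound 3 and a step that the two limits leave unreadable from compound 2 to compound 3, are each bounded by two limits and so cannot be sized in either direction.

The compound not yet measured is compound 4, `CCCC(=O)N1CCN(c2nc(=O)c3cc(C(F)(F)F)cc([N+](=O)[O-])c3s2)CC1`. It differs from compound 2 by propylcarbonyl in place of cyclohexylmethyl on an amine nitrogen in a ring. Of the measured steps, a step that the two limits leave unreadable from compound 1 to compound 2 and a step that the two limits leave unreadable from compound 2 to compound 3 also exchange the group on this ring nitrogen, one of them likewise trading an alkyl for an acyl group, yet neither could be read. Nothing measured here therefore points to a change beyond the scatter, and the step from compound 2 is expected to be a number no higher from compound 2 to compound 4 (the limit leaves the size open), most probably ending again at the limit.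

Compound 4 is accordingly estimated at 125000 nM in this assay, with a range from 60000 nM to 250000 nM.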

Compound 4, half-maximal cytotoxic concentration: > 125000 nM
Compound 4 ended at the assay's limit; the forecaster's own chance of this, stated with the estimate: 85%; the middle value sits exactly at the limit.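

No step between compound 4 and compound 1, compound 2 or compound 3 can be read, since each joins two limits in this assay: the limit of > 125000 nM in this assay, at which 4 of the 4 values shown sit.

The compounds shown leave open where the actual half-maximal cytotoxic concentration of each compound lies, and whether exchanging the group on the ring nitrogen changes it at all.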